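The compounds below may be only part of what the source reports. "The series", "measured", "known", "first", "only" and "open" are said of these compounds alone.

Measured so far:
compound 1 `Cc1cc(OC(C)(C)C)c(S(C)(=O)=O)cc1C(=O)N=C(N)N` — 9.4 nM in a functional assay for inhibition of sodium/hydrogen exchanger (Oryctolagus cuniculus); a lower number here means a stronger inhibitor, a higher number a weaker inhibitor
compound 2 `Cc1cc(Oc2cccc(Cl)c2)c(S(C)(=O)=O)cc1C(=O)N=C(N)N` — 21 nM in this assay
compound 3 `Cc1cc(N2CCCC2)c(S(C)(=O)=O)cc1C(=O)N=C(N)N` — 11 nM in this assay

All three numbers lie close together. Among the compounds with values here, compound 3 sits within the scatter of compound 1 (a 1.2-fold higher number from compound 1 to compound 3 (0.07 log units; within the scatter)) and within the scatter of compound 2 (a 1.9-fold lower number from compound 2 to compound 3 (0.28 log units; within the scatter)); the only step beyond the scatter is a 2.2-fold higher number from compound 1 to compound 2 (0.35 log units; beyond the scatter).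

Compound 4 `Cc1cc(N2CCC(N)CC2)c(S(C)(=O)=O)cc1C(=O)N=C(N)N` differs from compound 3 by 4-aminopiperidin-1-yl in place of pyrrolidin-1-yl on an aromatic carbon. The two steps that bear on this position, a 1.2-fold higher number from compound 1 to compound 3 (0.07 log units; within the scatter) and a 1.9-fold lower number from compound 2 to compound 3 (0.28 log units; within the scatter), show that exchanging the group here has so far moved the number little. No change beyond the scatter is therefore expected in this assay. The expected step is a 1.2-fold higher number from compound 3 to compound 4 (0.07 log units; within the scatter). Compound 4 is estimated at 13 nM, with a range from 5 nM to 35 nM.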

Compound 4, half-maximal inhibitory concentration: 9.8 nM
Beside the measured number, compound 4's estimate is 1.3-fold (0.12 log units) above it; measured number inside the range.
By their numbers in this assay, from the lowest: compounds 1, 4, 3 and 2 (each within the scatter of the next, the first and the last beyond it).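

In this assay the position keeps its number with a six-membered ring carrying an amino group and a hydrogen-bond donor, which the earlier groups lack: the change gives a 1.1-fold lower number from compound 3 to compound 4 (0.05 log units; within the scatter) and, against tert-butoxy, a 1.0-fold higher number from compound 1 to compound 4 (0.02 log units; within the scatter) in the same narrow band. Within the data shown here, the only step beyond the scatter is the modest one against 3-chlorophenoxy, a 2.1-fold lower number from compound 2 to compound 4 (0.33 log units; beyond the scatter) and compound 2 is the exception to that band.

Going by these compounds, whether a carboxylic acid or a longer chain ending in an amine would hold the number at this position stays open. Nothing available accounts for this tolerance.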